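The compounds below may be only part of what the source reports. "The series", "measured", "known", "first", "only" and "open" are said of these compounds alone.

Three compounds have been measured in an ADME assay on cells (Splenocyte, Mus musculus, strain BALB/c) for cytotoxicity, read by thymidine incorporation, with a stated time of 24 h; a lower number here means a stronger inhibitor, a higher number a weaker inhibitor:

Compound 1, `O=C(CCN1CCN(c2ccnc3cc(Cl)ccc23)CC1)N/N=C/c1c[nH]c2ccccc12`, gives 5700 nM.
Compound 2, `O=C(CCN1CCN(c2ccnc3cc(Cl)ccc23)CC1)N/N=C/c1ccccc1`, gives 300 nM.
Compound 3, `O=C(CCN1CCN(c2ccnc3cc(Cl)ccc23)CC1)N/N=C/c1ccc([N+](=O)[O-])cc1`, gives 12100 nM.

Compound 2 has the lowest number of the three. Moving from compound 1 to compound 2 gives a 19-fold lower number from compound 1 to compound 2 (1.28 log units; beyond the scatter), and moving from compound 2 to compound 3 gives a 40-fold higher number from compound 2 to compound 3 (1.61 log units; beyond the scatter), so both other compounds lie clearly away from it.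

Compound 4, `CC(C)c1ccc(/C=N/NC(=O)CCN2CCN(c3ccnc4cc(Cl)ccc34)CC2)cc1`, shares the core of compound 2 and differs from it in one place: isopropyl in place of hydrogen on an aromatic carbon. Going by the values given here, the measured step that bears most directly on this change is the one from compound 2 to compound 3, where a group was also put onto the same aromatic carbon of the six-membered ring, and the number rose sharply, a 40-fold higher number from compound 2 to compound 3 (1.61 log units; beyond the scatter). Isopropyl is a different kind of group from nitro, and no measured pair shows what an isopropyl does here. Among the compounds with values here, the one comparison available still points toward a higher number when this position is no longer hydrogen, so a rise in this assay is expected for compound 4, though a smaller one than for compound 3. Compound 4 is therefore estimated at 1500 nM, in the range 300 nM to 8000 nM, which would mean a 5.0-fold higher number from compound 2 to compound 4 (0.70 log units; beyond the scatter).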

Compound 4, half-maximal inhibitory concentration: 7900 nM
For compound 4 the middle estimate is 5.3-fold (0.72 log units) below the measured one, within the range that was stated.
By their numbers in this assay, from the lowest: compound 2; then compounds 1, 4 and 3 (each within the scatter of the next, the first and the last beyond it).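

In this assay, isopropyl on this aromatic carbon, para to a large group, also gives a large rise (a 26-fold higher number from compound 2 to compound 4 (1.42 log units; beyond the scatter)), so the rise seen earlier is not confined to the nitro group: two quite different groups placed here both move the number well away from that of the unsubstituted phenyl. The choice between these two groups makes no clear difference (a 1.5-fold lower number from compound 3 to compound 4 (0.19 log units; within the scatter)), as the gap lies within the scatter even though one group is built of carbon only and the other is not. The 4-isopropylphenyl compound also cannot be told apart from the indole compound (a 1.4-fold higher number from compound 1 to compound 4 (0.14 log units; within the scatter)), which leaves compound 2, with its plain phenyl, as the only one of the four standing clearly apart at the low end.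

Nothing available explains why a group at this position has such an effect. Still open, on these data alone, is whether a group smaller than isopropyl, such as methyl, or a group of another kind, such as an amine or a carboxylic acid, would keep the number near that of compound 2 or raise it in the same way.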